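The source may hold more compounds than are shown below. What is called first, only, known or untested is meant among the compounds shown, and "the series" means these compounds.

Series notes. In a functional assay on the whole organism (artery, strain albino) with Rattus norvegicus as the target, with a stated time of 30 min, at a dose of 10 mg/kg by the oral route (on this read-out lower numbers stand for less inhibition and higher numbers for more inhibition at the one dose given (going by the name of the read-out)), compound 1 `COc1ccc(C2N=C(SCc3ccccc3)NC(C)=C2C(=O)Nc2ccc(F)cc2)cc1OC` gives 3.6%, and compound 2 `CC1=C(C(=O)Nc2ccc(F)cc2)C(c2ccc([N+](=O)[O-])cc2)N=C(SCc2ccccc2)N1` gives 7.2%. Within the data shown here, both read-outs are small, and the only step within the measured pair, a number 3.6 percentage points higher from compound 1 to compound 2 (within the scatter), is within the scatter, so compound 2 and compound 1 stand side by side rather than in any order; compound 2 is simply the reference point for the next change.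

Compound 3 `CC1=C(C(=O)Nc2ccc(F)cc2)C(c2ccc([N+](=O)[O-])cc2)N=C(SCc2cccc(Cl)c2)N1` differs from compound 2 by chloro in place of hydrogen on an aromatic carbon. Among the measured compounds shown here, no measured step touches the benzyl; the single measured step swaps the aryl on the saturated ring carbon, so it tells nothing about a chloro entering the benzyl. For the measured compounds named here, with no step bearing on this change and both measured read-outs near the floor, the working expectation for compound 3 in this assay is no step beyond the scatter, and the estimated shift is a number 0.8 percentage points higher from compound 2 to compound 3 (within the scatter). Compound 3 is therefore expected to give about 8%, with the plausible range running from 0% to 22%.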

Compound 3, a percentage reported as inhibition, in the whole organism at one dose (the size of the read-out at that dose, not a potency): 4.1%
For compound 3 the middle estimate is 3.9 percentage points above the measured one; measured number inside the range.
By their numbers in this assay, from the lowest: compounds 1, 3 and 2 (each within the scatter of the next).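

In this assay, chloro in place of hydrogen on an aromatic carbon of the benzyl gives a number 3.1 percentage points lower from compound 2 to compound 3 (within the scatter), so at this one place 3-chlorobenzyl and benzyl cannot be told apart in this read-out. Among these compounds, this is the first measured change on the benzylsulfanyl side, where the earlier step concerned only the aryl on the saturated ring carbon, and now a change at each of these two places has left the numbers small and within the scatter of one another. No supporting measurement bears on this result, and it offers no account of what lies behind it.

From the compounds shown here alone, a single chloro says little about the benzyl as a whole, so it remains open whether this part of the molecule can move the read-out at all, for instance with an amine or a carboxylic acid on the same aromatic ring, or with a longer chain in place of the benzyl. Also open, going by these compounds, is whether any compound reaches a read-out clearly beyond the scatter of these three, without which no order among them can be drawn.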